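Trading isopropyl for 3-fluorophenyl on an amide-type nitrogen

The compounds below may be only part of what the source reports. "The series", "measured", "known", "first", "only" and "open" are said of these compounds alone.

In a functional assay on cells (Neutrophil, Homo sapiens) for inhibition, with a stated time of 10 min (a lower number here means a stronger inhibitor, a higher number a weaker inhibitor), two compounds have been measured so far. Compound 1 (`CCOC(=O)c1cnn(CC(C)O)c1NC(=O)Nc1cccc(F)c1`) gives 0.0007 nM. Compound 2 (`CCOC(=O)c1cnn(CC(O)CC)c1NC(=O)NC(C)C`) gives 0.0042 nM, the higher of the two numbers, and the gap lies beyond the scatter. These two compounds differ in more than one place, so the gap cannot be tied to any single change. Compound 3 (`CCOC(=O)c1cnn(CC(O)CC)c1NC(=O)Nc1cccc(F)c1`) arises from compound 2 with 3-fluorophenyl in place of isopropyl on an amide-type nitrogen. For the measured compounds named here, no measured pair isolates this change. Going by the values given here, the only guide is compound 1, which carries the same 3-fluorophenyl and gives 0.0007 nM, so a moderate move towards a lower number is expected in this assay. The estimated change is a 3.5-fold lower number from compound 2 to compound 3 (0.54 log units; beyond the scatter). For compound 3 the expected value is 0.0012 nM, with an estimated range of 0.0003 nM to 0.005 nM.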

Compound 3, half-maximal inhibitory concentration: 0.36 nM
Estimate against measurement, compound 3: 300-fold (2.48 log units) below, outside the stated range (above it).
By their numbers in this assay, from the lowest: compound 1; then compound 2; then compound 3.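

In this assay, 3-fluorophenyl in place of isopropyl on an amide-type nitrogen gives an 86-fold higher number from compound 2 to compound 3 (1.93 log units; beyond the scatter), so on this chain the isopropyl group holds the lower number. The 3-fluorophenyl group therefore does not bring a low number by itself: methyl in place of hydrogen on a saturated chain carbon, two bonds along the chain from an oxygen on a saturated carbon, gives a 510-fold higher number from compound 1 to compound 3 (2.71 log units; beyond the scatter), showing that the outcome with this group also depends strongly on that chain. The data offer no explanation for either step. The compounds shown leave open whether the isopropyl to 3-fluorophenyl step would run the same way on the chain of compound 1. They also leave open how cyclohexyl or benzyl on that nitrogen would compare.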